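The source may report more compounds than this note shows. Statements on the series, on what has been measured and on what is new or still open speak of the compounds shown alone.

Working notes on the series.

Going by the values given here, compound 2 `CCCCc1ccc(NC(=O)C2CCN(C/C=C/c3ccccc3)CC2)cc1` gives 5870 nM in a functional assay on MCF7 cells (Homo sapiens) for inhibition, read by MTT assay, with a stated time of 72 h (a lower number here means a stronger inhibitor, a higher number a weaker inhibitor), the lowest of the three numbers so far, though compound 1 `CC(C)c1ccc(NC(=O)C2CCN(C/C=C/c3ccccc3)CC2)cc1` with 9100 nM sits within the scatter of it. Compound 3 `COc1cccc(NC(=O)C2CCN(C/C=C/c3ccccc3)CC2)c1` gives 42700 nM in this assay and lies furthest from compound 2.

The next compound, compound 4 `N#Cc1ccc(NC(=O)C2CCN(C/C=C/c3ccccc3)CC2)cc1`, differs from compound 2 by cyano in place of butyl on an aromatic carbon.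

Among the compounds with values here, two measured steps bear on this. The step of a 1.6-fold lower number from compound 1 to compound 2 (0.19 log units; within the scatter) swapped one alkyl group for another and stayed within the scatter. The step of a 4.7-fold higher number from compound 1 to compound 3 (0.67 log units; beyond the scatter), the only one that removes an alkyl group from the amide-bound ring and brings in a hydrogen-bond acceptor, gave a modest higher number. Within the data shown here, compound 4 likewise loses an alkyl group and gains an acceptor, so a higher number in this assay is the more likely direction, though no measured step covers the cyano group itself and the size is uncertain.

The step from compound 2 is estimated as a 2.6-fold higher number from compound 2 to compound 4 (0.41 log units; beyond the scatter), a modest rise. For compound 4 the expected value in this assay is 15000 nM, with a range from 5000 nM to 50000 nM.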

Compound 4, half-maximal inhibitory concentration: 44500 nM
For compound 4 the middle estimate is 3.0-fold (0.47 log units) below the measured one, within the range that was stated.
By their numbers in this assay, from the lowest: compounds 2 and 1 (each within the scatter of the next); then compounds 3 and 4 (each within the scatter of the next).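

In this assay, the aromatic carbon para to a large group now shows a clear response to its substituent: butyl and isopropyl stay within the scatter of each other, whereas cyano gives a 7.6-fold higher number from compound 2 to compound 4 (0.88 log units; beyond the scatter) and a 4.9-fold higher number from compound 1 to compound 4 (0.69 log units; beyond the scatter), both beyond the scatter. Going by these compounds alone, the change from 3-methoxyphenyl to 4-cyanophenyl on the amide-type nitrogen, a 1.0-fold higher number from compound 3 to compound 4 (0.02 log units; within the scatter), lies within the scatter, so the four compounds fall into two groups: compounds 1 and 2, which carry an alkyl group on the ring, and compounds 3 and 4, which do not, with no compound here going against that split. No measured information on hand accounts for the step from butyl to cyano.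

The series leaves open whether the higher number belongs to the nitrile itself or simply to the absence of an alkyl group at this position. A methyl group, a longer chain such as hexyl, or a chlorine atom or an amine on the same carbon would separate these two readings and show how far the alkyl trend extends.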